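Methyl on a phenyl of an inactive pair

The compounds below may be only part of what the source reports. "The series", "measured", "known", "first", "only" and "open" are said of these compounds alone.

Measured in a functional assay on NCI/ADR-RES cells (Homo sapiens) for inhibition, read by sulforhodamine B assay, with a stated time of 48 h; on this read-out lower numbers stand for stronger inhibition of growth and higher numbers for weaker inhibition of growth:
Compound 1 `Cc1nnc(-c2nn(-c3ccccc3)c(-c3ccccc3)c2C#N)c2cn(-c3ccccc3)nc12`: > 100000 nM (a limit)
Compound 2 `N#Cc1c(-c2nnc(-c3ccccc3)c3nn(-c4ccccc4)cc23)nn(-c2ccccc2)c1-c1ccccc1`: > 100000 nM (a limit)

Compound 2 gives > 100000 nM, which is a limit and not a number. Among the compounds with values here, it therefore has no exact place, and the same holds for the only other compound measured, as the limit of > 100000 nM in this assay, at which 2 of the 2 values shown sit, shows.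

Compound 3 `Cc1ccc(-n2cc3c(-c4nn(-c5ccccc5)c(-c5ccccc5)c4C#N)nnc(-c4ccccc4)c3n2)cc1` differs from compound 2 by one change, (methyl in place of hydrogen on an aromatic carbon). In words, this is methyl in place of hydrogen on an aromatic carbon, para to a large group, turning phenyl to 4-methylphenyl.

Within the data shown here, only one measured step is available, and it lies at a different place on the core: a step that the two limits leave unreadable from compound 1 to compound 2. Among the measured compounds shown here, it gives no size to carry over, and no measured step covers this methyl change. With both measured compounds at the limit in this assay, growth inhibition is not expected to appear with so small a change, and a report of a limit again is the likeliest outcome.

The expected a number no higher from compound 2 to compound 3 (the limit leaves the size open) is no readable shift in either direction. For compound 3 the estimated value is 100000 nM. The expected range runs from 40000 nM to 200000 nM.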

Compound 3, concentration for 50% growth inhibition: 74700 nM
Estimate against measurement, compound 3: 1.3-fold (0.13 log units) above; measured number inside the range.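

In this assay, within the data shown here, compound 3 is the first to give a number and not a limit, so phenyl to 4-methylphenyl is the first change here with a readable floor. The change gives an at least 1.3-fold lower number from compound 2 to compound 3 (0.12 log units; that floor lies within the scatter); with the floor inside the usual scatter, this methyl, para to a large group, cannot yet be credited with any gain in growth inhibition. The only other step, at a different place on the core, cannot be read, and most of the series still gives no number: the limit of > 100000 nM in this assay, at which 2 of the 3 values shown sit.

As far as these compounds go, the true size of the methyl step stays open, and so does whether it lies beyond the scatter at all. Also open, from the compounds shown here alone, is whether an ethyl chain, a methoxy group, an amine or a carboxylic acid in place of the methyl would bring a clearer reading, and whether the same methyl on another phenyl of the shared core would give any number.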